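A larger aromatic group on the shared core, tested for cytotoxicity

The source may hold more compounds than are shown below. What is called first, only, known or untested is meant among the compounds shown, and "the series" means these compounds.

Of the compounds shown here, three of one family have been tested in an ADME assay on HepG2 cells (Homo sapiens) for cytotoxicity, read by CellTiter-Glo and resazurin assay, with a stated time of 72 h; a lower number here means that less compound is needed, a higher number that more compound is needed for the effect. Compound 1 `CC(C)N(Cc1cccc(OCCCCCC(=O)O)c1)C(=O)c1ccc(-c2ccc3c(c2)OCCO3)cc1` returns only a limit there, > 21900 nM. Compound 2 `CCOC(=O)CCCCCOc1cccc(CN(C(=O)c2ccc(-c3ccoc3)cc2)C(C)C)c1` likewise returns only a limit, > 26000 nM. Compound 3 `CCOC(=O)CCCCCOc1cccc(CN(C(=O)c2ccc(-c3ccco3)cc2)C(C)C)c1` also gives only a limit, > 26000 nM. For the measured compounds named here, the one step between close neighbours, a step that the two limits leave unreadable from compound 2 to compound 3, cannot be sized because the limit of > 26000 nM in this assay, at which 2 of the 3 values shown sit, is where both of its values sit; together with the limit of > 21900 nM in this assay, at which 1 of the 3 values shown sits, this leaves every value shown as a limit rather than a number. Compound 3 thus stands among values that are all limits, with no number of its own.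

Compound 4 `CCOC(=O)CCCCCOc1cccc(CN(C(=O)c2ccc(-c3ccc4c(c3)OCCO4)cc2)C(C)C)c1` differs from compound 3 in one place: 2,3-dihydro-1,4-benzodioxin-6-yl in place of furan-2-yl on an aromatic carbon. Compound 1 carries this same entering group and also returns only a limit. Going by the values given here, no measured step reaches beyond a limit, so no shift beyond the scatter is expected. The estimate for compound 4 in this assay is 30000 nM, in a range from 15000 nM to 100000 nM, which means an expected step that the limit leaves unreadable from compound 3 to compound 4 that amounts to essentially none.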

Compound 4, half-maximal effective concentration: > 24400 nM
Compound 4: no number, only a limit; the forecaster's own chance of this, stated with the estimate: 85%; the middle value lies beyond the limit too.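

In this assay compound 4 gives only a limit, > 24400 nM. Compound 1, compound 2 and compound 3 also give only limits, so none of their steps to compound 4 can be read. The compounds shown leave open what any of them would actually measure, and whether exchanging these groups changes that value at all.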